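The compounds below may be only part of what the source reports. "The series", "measured", "known", "first", "only" and "open" are said of these compounds alone.

Compound 2 `CCN(CC)c1ccc2cc(C(=O)c3ccc(N4CCN(C(=O)CN5CCN(S(=O)(=O)c6ccc(OC(F)(F)F)cc6)CC5)CC4)cc3)oc2c1` is the point of departure. Going by the values given here, in a functional assay on HCT-116 cells (Homo sapiens) for cytotoxicity, read by MTT assay, with a stated time of 48 h (a lower number here means a stronger inhibitor, a higher number a weaker inhibitor), compound 2 gives 7680 nM, the only plain number among the two values measured so far. Compound 1 `CCN(CC)c1ccc2cc(C(=O)c3ccc(N4CCN(C(=O)CN5CCN(S(=O)(=O)C6CC6)CC5)CC4)cc3)oc2c1` carries a cyclopropyl on the sulfonyl sulfur where compound 2 carries a 4-(trifluoromethoxy)phenyl. In this assay compound 1 reaches only a limit, > 40000 nM. The swap of that cyclopropyl for the aryl group gave an at least 5.2-fold lower number from compound 1 to compound 2 (0.71 log units; beyond the scatter), a step whose size is open-ended owing to the limit of > 40000 nM in this assay, at which 1 of the 2 values shown sits. Compound 3 `CCN(CC)c1ccc2cc(C(=O)c3ccc(N4CCN(C(=O)CN5CCN(S(=O)(=O)c6ccc(C(F)(F)F)cc6)CC5)CC4)cc3)oc2c1` has not yet been measured; it differs from compound 2 by trifluoromethyl in place of trifluoromethoxy on an aromatic carbon. Among the compounds with values here, no measured step bears directly on this change, since the single step measured exchanges the whole group on the sulfonyl sulfur rather than one substituent on the ring. The step is therefore expected to stay within the usual scatter, with a 1.1-fold lower number from compound 2 to compound 3 (0.04 log units; within the scatter). Compound 3 is expected to give about 7000 nM, somewhere between 3000 nM and 20000 nM.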

Compound 3, half-maximal inhibitory concentration: 32200 nM
Beside the measured number, compound 3's estimate is 4.6-fold (0.66 log units) below it, outside the stated range (above it).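

In this assay, losing only the oxygen of the trifluoromethoxy group gives a 4.2-fold higher number from compound 2 to compound 3 (0.62 log units; beyond the scatter). The earlier step exchanged the whole group on the sulfonyl sulfur, so it could not show that one small substituent change on the aromatic ring, para to a large group, can move the number beyond the scatter. Placing 4-(trifluoromethyl)phenyl on the sulfonyl sulfur instead of cyclopropyl gives an at least 1.2-fold lower number from compound 1 to compound 3 (0.09 log units; that floor lies within the scatter), and whether this aryl group brings any gain over cyclopropyl stays unclear because that step is open-ended: the limit of > 40000 nM in this assay, at which 1 of the 3 values shown sits.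

The compounds shown leave open whether the oxygen itself matters or only the complete trifluoromethoxy group, which a methoxy group or a plain methyl at this ring position would help to separate. Going by these compounds, whether the difference between these substituents holds in other cell lines also remains open.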